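The source may report more compounds than this note shows. Statements on the series, on what has been measured and on what is new or still open speak of the compounds shown alone.

Measured in a functional assay on KYSE-70 cells for antiproliferative activity against KYSE-70 cell line (Homo sapiens), read by MTT assay, with a stated time of 72 h; a lower number here means a stronger inhibitor, a higher number a weaker inhibitor:

- Compound 1 `COc1ccc(NC(=O)c2cc(=O)[nH]c3cc(Br)ccc23)cc1`: > 20000 nM (a limit)
- Compound 2 `O=C(Nc1ccccn1)c1cc(=O)[nH]c2cc(Br)ccc12`: 11000 nM
- Compound 3 `O=C(Nc1ccc(F)cc1)c1cc(=O)[nH]c2cc(Br)ccc12`: > 20000 nM (a limit)

Compound 3 gives > 20000 nM, which is a limit and not a number. For the measured compounds named here, its true position is therefore unknown, and the series so far shows (the limit of > 20000 nM in this assay, at which 2 of the 3 values shown sit). Only compound 2 has a measured number, at 11000 nM.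

Compound 4 `O=C(Nc1ccc(C(F)(F)F)cc1)c1cc(=O)[nH]c2cc(Br)ccc12` carries trifluoromethyl in place of fluoro on an aromatic carbon. The nearest measured change is fluoro in place of methoxy on an aromatic carbon, which gives a step that the two limits leave unreadable from compound 1 to compound 3. Going by the values given here, the only other change, 4-fluorophenyl in place of pyridin-2-yl on an amide-type nitrogen, gives an at least 1.8-fold higher number from compound 2 to compound 3 (0.25 log units; that floor lies within the scatter). It concerns a different part of the molecule, so it says little about the new change.

Neither step shows a size or direction that can be carried over, so no step beyond the scatter is expected in this assay, and another limit is the likeliest report. The expected change is a number no higher from compound 3 to compound 4 (the limit leaves the size open). Compound 4 is estimated at 20000 nM, with an expected range from 9000 nM to 45000 nM.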

Compound 4, half-maximal inhibitory concentration: > 20000 nM
Compound 4: only a limit was reported (the forecaster's own chance of this, stated with the estimate: 65%); the middle value sits exactly at the limit.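

In this assay compound 4 gives > 20000 nM, which is a limit and not a number. Compound 1 and compound 3 also carry limits, so no step among these three compounds can be read: the limit of > 20000 nM in this assay, at which 3 of the 4 values shown sit.

The compounds shown leave open whether methoxy, fluoro and trifluoromethyl differ at all in this assay.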